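Aryl swap at the cyano-flanked position of the shared core

A few compounds are considered here, and "the series" means these few. Any claim that something is new, unique, unknown or untested is made for them only; others in the source may bear on it.

Measured so far:
compound 1 `CCOC(=O)c1cnn(-c2nc(-c3ccc(OC)cc3)c(C#N)c(=O)n2C)c1N` — 59 ug/mL
compound 2 `CCOC(=O)c1cnn(-c2nc(-c3ccccc3O)c(C#N)c(=O)n2C)c1N` — 48 ug/mL
compound 3 `CSc1nc(-c2cccs2)c(C#N)c(=O)n1C` — 71 ug/mL

In a functional assay, with a stated time of 20 min (on this read-out higher numbers stand for weaker inhibition and lower numbers for stronger inhibition), compound 2 gives the lowest of the three numbers, yet both neighbours sit within the scatter: compound 1 is nearest and compound 3 furthest, so no order among the three can be claimed.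

The next compound, compound 4 `CCOC(=O)c1cnn(-c2nc(-c3cccs3)c(C#N)c(=O)n2C)c1N`, differs from compound 2 in one place: thiophen-2-yl in place of 2-hydroxyphenyl on an aromatic carbon.

For the measured compounds named here, only one measured step touches this position. a 1.2-fold lower number from compound 1 to compound 2 (0.09 log units; within the scatter) shows that exchanging one aryl group for another on this carbon left this assay unmoved. Going by the values given here, compound 3 also carries thiophen-2-yl at the same place, though on a core that differs elsewhere, and in this assay compound 3 gives 71 ug/mL, again within the scatter of compound 2; no single-point step between compound 3 and compound 4 exists, so it serves only as a loose pointer.

On this basis the change is expected to produce no step beyond the scatter, a 1.2-fold higher number from compound 2 to compound 4 (0.08 log units; within the scatter). Compound 4 is therefore estimated at 58 ug/mL, with a range from 30 ug/mL to 115 ug/mL.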

Compound 4, half-maximal inhibitory concentration: 79 ug/mL
The estimate for compound 4 lay 1.4-fold (0.13 log units) below the measured number, within the range that was stated.
By their numbers in this assay, from the lowest: compounds 2, 1, 3 and 4 (each within the scatter of the next).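

In this assay, the aromatic carbon ortho to a cyano group now carries three different aryl groups on the shared core, and thiophen-2-yl stays within the scatter of both six-membered aryl groups (a 1.6-fold higher number from compound 2 to compound 4 (0.22 log units; within the scatter); a 1.3-fold higher number from compound 1 to compound 4 (0.13 log units; within the scatter)). At this position, a six-membered aromatic ring of carbon only can therefore be replaced by a five-membered aromatic ring with 1 hetero atom without a step beyond the scatter on this read-out. The same holds when the hydrogen-bond donor of 2-hydroxyphenyl leaves with the group, so neither that donor nor the ring size is shown to matter here, and no separate data offer an explanation for the flat result.

The compounds shown hold only aryl groups on this carbon, so it remains open whether an amine, a carboxylic acid or a longer alkyl chain there would give a step beyond the scatter. Unsubstituted phenyl would also be informative, as it would compare the six-membered ring directly with thiophen-2-yl, without a hydroxy or methoxy group on the ring.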